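Swapping the Fluorophenyl for Methoxyphenyl in Compound 2

The source may hold more compounds than are shown below. What is called first, only, known or untested is meant among the compounds shown, and "the series" means these compounds.

Compound 1 `NC(=O)N1CCN(C(=S)SCc2cn(Cc3ccccc3F)nn2)CC1` sits at the limit of > 128000 nM in this assay, at which 1 of the 2 values shown sits, in a functional assay on MCF7 cells (Homo sapiens) for cytotoxicity, read by MTT assay, with a stated time of 72 h; a lower number here means a stronger inhibitor, a higher number a weaker inhibitor. In this assay compound 1 shows > 128000 nM, a limit rather than a number. Compound 2 `CCN(C)C(=O)N1CCN(C(=S)SCc2cn(Cc3ccccc3F)nn2)CC1` gives 7210 nM in this assay, the only number shown. The step of an at least 17-fold lower number from compound 1 to compound 2 (1.24 log units; beyond the scatter) concerns the carbonyl substituent, not the benzyl part. Compound 3 `CCN(C)C(=O)N1CCN(C(=S)SCc2cn(Cc3ccc(OC)cc3)nn2)CC1` differs from compound 2 by 4-methoxyphenyl in place of 2-fluorophenyl on a saturated chain carbon bound to an aromatic nitrogen. Among the measured compounds shown here, no measured step touches this position, so only a change within the scatter is expected, a 1.0-fold higher number from compound 2 to compound 3 (0.02 log units; within the scatter). Compound 3 is therefore estimated at 7500 nM, between 2500 nM and 25000 nM.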

Compound 3, half-maximal inhibitory concentration: 21400 nM
For compound 3 the middle estimate is 2.9-fold (0.46 log units) below the measured one; the measured number falls inside the stated range.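

The benzyl part is not a silent position: changing 2-fluorobenzyl to 4-methoxybenzyl gives a 3.0-fold higher number from compound 2 to compound 3 (0.47 log units; beyond the scatter) and so makes compound 3 the weaker inhibitor of the pair. Until now, only the carbonyl substituent had been seen to move the number, and this second step is the smaller of the two. Nothing measured here gives a reason for this shift.

The swap changes both the substituent and its ring position at once, so the two effects remain unseparated. Plain benzyl, 4-fluorobenzyl and 2-methoxybenzyl would help to tell them apart.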